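The source may hold more compounds than are shown below. What is called first, only, known or untested is meant among the compounds shown, and "the series" means these compounds.

Compound 3 `CCOC(=O)C1=Cc2ccccc2OC1(OCc1cc(-c2ccc(Br)cc2)no1)C(F)(F)F`: 52300 nM. Compound 1 `CCOC(=O)C1=Cc2ccccc2OC1(OCc1cc(-c2ccc3ccccc3c2)no1)C(F)(F)F`: > 150000 nM. Compound 2 `O=C(O)C1=Cc2ccccc2OC1(OCc1cc(-c2ccc([N+](=O)[O-])cc2)no1)C(F)(F)F`: > 150000 nM.

For the measured compounds named here, in a functional assay on HeLa cells (Homo sapiens) for inhibition, read by MTT assay, with a stated time of 24 h (on this read-out higher numbers stand for weaker inhibition and lower numbers for stronger inhibition), compound 3 gives 52300 nM, the only actual number among the three. For compound 1 the value > 150000 nM is a limit of the assay. For compound 2 the value > 150000 nM is likewise a limit. Going by the values given here, the one measured step, an at least 2.8-fold lower number from compound 1 to compound 3 (0.45 log units; beyond the scatter), is the only change that moved the read-out, and it concerns a different position from the one now in question. Compound 4 `CCOC(=O)C1=Cc2ccccc2OC1(OCc1cc(-c2ccc([N+](=O)[O-])cc2)no1)C(F)(F)F` differs from compound 3 by nitro in place of bromo on an aromatic carbon. Among the compounds with values here, no measured step bears directly on this exchange, so the expectation rests on compound 3 alone, with the limit of > 150000 nM in this assay, at which 2 of the 3 values shown sit, marking where two neighbours sit. Compound 4 is therefore expected at 80000 nM, between 30000 nM and 200000 nM, a step of a 1.5-fold higher number from compound 3 to compound 4 (0.18 log units; within the scatter) that is not expected to exceed the scatter.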

Compound 4, half-maximal inhibitory concentration: > 150000 nM
Compound 4 ended at the assay's limit; the forecaster's own chance of this, stated with the estimate: 35%; middle value at least 1.8-fold (0.27 log units) from the limit.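

In this assay, the change from 4-bromophenyl to 4-nitrophenyl gives an at least 2.8-fold higher number from compound 3 to compound 4 (0.45 log units; beyond the scatter), so a single group exchange on this aromatic ring moves the read-out, not only replacement of the whole aryl group. Of the groups tried here, only bromo gives a real number. The steps to compound 4 from compound 1 and compound 2 cannot be read, and the series gathers at one ceiling: the limit of > 150000 nM in this assay, at which 3 of the 4 values shown sit.

Going by these compounds, whether chloro, an amine or a methoxy group at this place would give a measurable number remains open. Also open, on these data alone, is how a carboxylic acid in place of the ethyl ester would behave alongside 4-bromophenyl.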